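Amide nitrogen change from compound 2 to compound 3

A few compounds are considered here, and "the series" means these few. Any claim that something is new, unique, unknown or untested is made for them only; others in the source may bear on it.

In an ADME assay on MRC5 cells (Homo sapiens) for inhibition, with a stated time of 72 h (on this read-out lower numbers stand for an effect already at smaller amounts and higher numbers for an effect only at larger amounts of compound), compound 1 `COc1cccc(OC)c1C(=O)Nc1c[nH]nc1C(=O)NCCN1CCCC1` reads > 50000 nM as a limit of the assay, not a number. Compound 2 `COCCNC(=O)c1n[nH]cc1NC(=O)c1c(OC)cccc1OC` reads > 50000 nM as a limit too, and so stands where both values shown sit (the limit of > 50000 nM in this assay, at which 2 of the 2 values shown sit). Compound 3 `COc1cccc(OC)c1C(=O)Nc1c[nH]nc1C(=O)Nc1ccncc1` carries pyridin-4-yl in place of 2-methoxyethyl on an amide-type nitrogen on the amide-type nitrogen. Among the compounds with values here, the only measured step is a step that the two limits leave unreadable from compound 1 to compound 2 and it sets no size. The expected change is an at least 1.2-fold lower number from compound 2 to compound 3 (0.09 log units; that floor lies within the scatter) as an estimate, toward lower numbers if any is seen. For compound 3 the estimate is 40000 nM within an expected range of 12000 nM to 50000 nM and another reading at the limit is likely.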

Compound 3, half-maximal effective concentration: > 50000 nM
Compound 3 gave a limit, no number; the forecaster's own chance of this, stated with the estimate: 65%; at least 1.2-fold (0.09 log units) between middle value and limit.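

No step can be read among compound 1, compound 2 and compound 3, since each gives a limit and not a number: the limit of > 50000 nM in this assay, at which 3 of the 3 values shown sit.

The compounds shown leave open whether any group on the amide-type nitrogen shifts this read-out at all.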